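The source may report more compounds than this note shows. Statements on the series, on what has been measured and on what is new or still open speak of the compounds shown alone.

Measured in a physicochemical assay for lipophilicity, using the shake flask method, in phosphate buffer, measured as octanol-water partition, with a stated time of 2 h, at pH 7.4, tested at 1 uM; a lower number here means a more polar compound, a higher number a more lipophilic compound:
- compound 1 `O=[N+]([O-])c1ccc2c(ccn2-c2ccc(O[C@H]3O[C@H](CO)[C@@H](O)[C@H](O)[C@@H]3O)c(Cl)c2)c1`: 1.8
- compound 2 `O=[N+]([O-])c1ccc2c(ccn2-c2ccc(O[C@H]3O[C@H](CO)[C@@H](O)[C@H](O)[C@@H]3O)c(F)c2)c1`: 1.9

Among the compounds with values here, only these two compounds have numbers so far, and they lie within the scatter of each other. Compound 1 therefore has just one neighbour, with a number 0.10 log units higher from compound 1 to compound 2 (within the scatter). The next compound is compound 3 `COC(=O)c1ccc2c(ccn2-c2ccc(O[C@H]3O[C@H](CO)[C@@H](O)[C@H](O)[C@@H]3O)c(Cl)c2)c1`, and the change is methoxycarbonyl in place of nitro on an aromatic carbon. Within the data shown here, the single measured step, a number 0.10 log units higher from compound 1 to compound 2 (within the scatter), is fluoro in place of chloro, a different exchange at a different place, so it bears on this change only weakly. Among the measured compounds shown here, no measured step shows what this exchange does, so the range must stay wide. A slightly higher number is expected, but nothing beyond the scatter. The estimated step is a number 0.20 log units higher from compound 1 to compound 3 (within the scatter). For compound 3 the expected value is 2, with an estimated range of 1.5 to 2.5.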

Compound 3, distribution coefficient: 2.8
Estimate against measurement, compound 3: 0.80 log units below, and the stated range ends below it.
By their numbers in this assay, from the lowest: compounds 1 and 2 (each within the scatter of the next); then compound 3.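

In this assay, within the data shown here, the exchange of nitro for methoxycarbonyl on this aromatic carbon gives a clear step (a number 1.00 log units higher from compound 1 to compound 3 (beyond the scatter)), whereas the only earlier step, fluoro in place of chloro elsewhere on the molecule, stayed within the scatter. The position meta to a fused ring and para to a fused ring is thus the first place in this short series where a single exchange moves the number beyond the scatter, even though the two groups match in hydrogen-bond donors, hydrogen-bond acceptors and net charge. Nothing on hand accounts for the size of this step.

On these data alone, it remains open how a nitrile, an amide or a carboxylic acid would compare at this place. As far as these compounds go, it is also open whether fluoro in place of chloro would remain as small a step with methoxycarbonyl present.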